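Thioamide Analogue in the Trachea Series

This account rests on a few compounds, and the source may have more. Where it says the series, first, only, none or still open, it means among the compounds named here.

Compound 1 `CC1(C)C=C(n2ccccc2=O)c2cc(C(=O)c3ccccc3)ccc2O1` gives 6.21 in a functional assay (trachea) with Rattus norvegicus as the target; on this read-out higher numbers stand for higher potency (the scale is a negative logarithm) and lower numbers for lower potency. Among the compounds with values here, compound 2 `CC1(C)C=C(n2ccccc2=O)c2cc(O)ccc2O1` gives 5.31 in this assay, so compound 2 stands lowest of the two numbers known, its nearest neighbour being compound 1. Within the data shown here, the one step measured so far runs a number 0.90 log units lower from compound 1 to compound 2 (beyond the scatter). Compound 3 `CC1(C)C=C(n2ccccc2=O)c2cc(C(=N)S)ccc2O1` is not yet measured. Among the measured compounds shown here, it differs from compound 2 as follows: a group of 3 heavy atoms (1 carbon, 1 nitrogen, 1 sulfur; no ring) in place of one oxygen atom, on an aromatic carbon The only step that bears on this change is the one from compound 1 to compound 2, which was modest and beyond the scatter; no step compares hydroxy against the entering group directly, so the expectation rests on that single step alone. A step of modest size upward is expected, a number 0.39 log units higher from compound 2 to compound 3 (beyond the scatter). Compound 3 is therefore estimated at 5.7 in this assay, within a range from 5.1 to 6.3.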

Compound 3, logarithm of the reciprocal of the active concentration, log(1/C): 5.96
Beside the measured number, compound 3's estimate is 0.26 log units below it; the measured number falls inside the stated range.
By their numbers in this assay, from the lowest: compound 2; then compounds 3 and 1 (each within the scatter of the next).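

Putting the group of 3 heavy atoms in place of hydroxy on this aromatic carbon gives, in this assay, a number 0.65 log units higher from compound 2 to compound 3 (beyond the scatter), so a second group now stands clear of hydroxy at this position. Against benzoyl the same group gives a number 0.25 log units lower from compound 1 to compound 3 (within the scatter), so among these compounds the six-membered aromatic ring of benzoyl is not required for a number at this level. Nothing measured here explains either step.

The compounds shown leave open which part of the entering group, its sulfur, its nitrogen or its double bond, goes with the higher number, a question that a primary amide or a nitrile at this position would address. They also leave open how a plain hydrogen or a methoxy group would compare there.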